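This account rests on a few compounds, and the source may have more. Where it says the series, first, only, none or still open, it means among the compounds named here.

Measured compounds:
compound 1 `Clc1ccc(C2CNCCNCCNCCN2)cc1` – 181000 nM
compound 2 `FC(F)(F)c1cc(C2CNCCNCCNCCN2)cc(C(F)(F)F)c1` – 61000 nM

In an ADME assay on HEK293 cells (Homo sapiens) for cytotoxicity (on this read-out higher numbers stand for an effect only at larger amounts of compound and lower numbers for an effect already at smaller amounts), compound 1 gives 181000 nM and holds the highest of the two numbers. Its nearest neighbour, compound 2, gives 61000 nM in this assay, a lower number by more than the scatter. Compound 3 `c1ccc(C2CNCCNCCNCCN2)cc1` has not been measured. It differs from compound 1 by hydrogen in place of chloro on an aromatic carbon. Within the data shown here, no step between measured compounds matches this change. The expected step of a 1.3-fold higher number from compound 1 to compound 3 (0.10 log units; within the scatter) in this assay is small, towards a higher number, and may not exceed the scatter. Compound 3 is estimated at 230000 nM in this assay, within 110000 nM to 480000 nM.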

Compound 3, half-maximal effective concentration: > 200000 nM
Compound 3 was reported as a limit; the forecaster's own chance of this, stated with the estimate: 30%; the middle value does not contradict the limit.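

In this assay, hydrogen in place of chloro on an aromatic carbon, para to a large group, gives an at least 1.1-fold higher number from compound 1 to compound 3 (0.04 log units; that floor lies within the scatter). For compound 3 the reading of > 200000 nM is a limit of the assay, not a number. Losing the chloro group at this place therefore brings no lower number, while the true size of the step stays unread, the reading being capped: the limit of > 200000 nM in this assay, at which 1 of the 3 values shown sits.

On these data alone, the exact value of compound 3 remains open. Also open, as far as these compounds go, is what an amine, a carboxylic acid or a methoxy group at this place would give in this assay.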